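From 1-benzofuran-2-yl to ethynyl: compound 3 to compound 4

The source may report more compounds than this note shows. Statements on the series, on what has been measured and on what is new or still open speak of the compounds shown alone.

Among the compounds with values here, in an ADME assay on MRC5 cells (Homo sapiens), read by MTT assay, with a stated time of 72 h (a higher number here means a weaker inhibitor, a lower number a stronger inhibitor), compound 3 `Cc1ncnc2c1c(-c1cc3ccccc3o1)cn2[C@@H]1O[C@H](CO)[C@@H](O)[C@H]1O` gives 84400 nM, the higher of the two exact numbers so far, and compound 2 `C#Cc1cn([C@@H]2O[C@H](CO)[C@@H](O)[C@H]2O)c2ncnc(N(C)C)c12` gives 36100 nM. Compound 1 `C#Cc1cn([C@@H]2O[C@H](CO)[C@@H](O)[C@H]2O)c2ncnc(SC)c12` reports only a limit, > 100000 nM. Compound 4 `C#Cc1cn([C@@H]2O[C@H](CO)[C@@H](O)[C@H]2O)c2ncnc(C)c12` has ethynyl in place of 1-benzofuran-2-yl on an aromatic carbon. Within the data shown here, no measured step makes this change. The only measured one, an at least 2.7-fold lower number from compound 1 to compound 2 (0.44 log units; beyond the scatter), swaps other groups and so bears on it only loosely. Compound 2 already carries ethynyl at 36100 nM, which suggests a modest fall in this assay. The expected step is a 2.1-fold lower number from compound 3 to compound 4 (0.32 log units; beyond the scatter). Compound 4 is estimated at 40000 nM, with an expected range of 10000 nM to 100000 nM.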

Compound 4, half-maximal inhibitory concentration: 1440 nM
Compound 4: middle estimate off by 28-fold (1.44 log units), on the high side, and the stated range ends above it.
By their numbers in this assay, from the lowest: compound 4; then compound 2; then compound 3. At a limit, above all of these: compound 1.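

In this assay, within the data shown here, ethynyl in place of 1-benzofuran-2-yl on this aromatic carbon gives a 59-fold lower number from compound 3 to compound 4 (1.77 log units; beyond the scatter) and so counts for far more than the earlier compounds suggested. Ethynyl alone is not enough: with it held fixed, methyl in place of dimethylamino gives a 25-fold lower number from compound 2 to compound 4 (1.40 log units; beyond the scatter) and shows that, among these compounds, the lowest number needs both ethynyl and methyl. Methyl in place of methylsulfanyl gives an at least 69-fold lower number from compound 1 to compound 4 (1.84 log units; beyond the scatter) as a step that rests on a limit: the limit of > 100000 nM in this assay, at which 1 of the 4 values shown sits.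

From the compounds shown here alone, whether the triple bond itself matters stays open, since no other small group, such as ethyl or a nitrile, sits on this carbon. An ethyl group or an amine in place of methyl is also absent from the compounds shown.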